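The compounds below may be only part of what the source reports. "The series", "measured", "known", "first", "only" and "open" are said of these compounds alone.

Compound 3 `COc1ccc(-c2nnc(N3CCN(C(=O)CN4CCN(c5ccc(OC)cc5)CC4)CC3)nc2-c2ccc(OC)cc2)cc1` anchors the series. In an ADME assay on NIH3T3 cells (Mus musculus) for cytotoxicity, read by MTT assay, with a stated time of 24 h (on this read-out higher numbers stand for weaker inhibition and lower numbers for stronger inhibition), compound 3 gives only a limit, > 821000 nM. Compound 1 `COc1ccc(-c2nnc(N3CCN(C(=O)CN4CCN(c5cccc(OC)c5)CC4)CC3)nc2-c2ccc(OC)cc2)cc1` likewise gives only a limit in this assay, > 821000 nM. Compound 2 `COc1ccc(-c2nnc(N3CCN(C(=O)CN4CCN(c5cccc(Cl)c5)CC4)CC3)nc2-c2ccc(OC)cc2)cc1` too gives only a limit in this assay, > 814000 nM. Since every value sits at a limit, the limit of > 814000 nM in this assay, at which 1 of the 3 values shown sits, or (the limit of > 821000 nM in this assay, at which 2 of the 3 values shown sit), the steps a step that the two limits leave unreadable from compound 1 to compound 3 and a step that the two limits leave unreadable from compound 2 to compound 3 carry no readable size. Compound 4 `COc1ccc(-c2nnc(N3CCN(C(=O)CN4CCN(c5ccc(Cl)cc5)CC4)CC3)nc2-c2ccc(OC)cc2)cc1` differs from compound 3 by chloro in place of methoxy on an aromatic carbon. Going by the values given here, the one measured step of the same kind, a step that the two limits leave unreadable from compound 1 to compound 2, bears on it directly but is itself unreadable in size. Nothing in the data therefore points to a step beyond the scatter in this assay. Compound 4 is expected to return a limit again, estimated at 821000 nM with a range of 400000 nM to 2000000 nM. The expected step is a number no higher from compound 3 to compound 4 (the limit leaves the size open).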

Compound 4, half-maximal inhibitory concentration: > 814000 nM
Compound 4 ended at the assay's limit; the forecaster's own chance of this, stated with the estimate: 90%; the middle value lies beyond the limit too.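

Going by these compounds alone, compound 1, compound 2, compound 3 and compound 4 all stand at limits in this assay, so no step among them can be read. The compounds shown leave open whether chloro in place of methoxy, or either substitution position, changes the read-out at all.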